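A few compounds are considered here, and "the series" means these few. Any claim that something is new, unique, unknown or untested is made for them only; others in the source may bear on it.

Compound 3 `Cc1nn(-c2ncnc3nc[nH]c23)c2c1C(OCc1ccc(C#N)cc1)CC(=O)N2` gives 4 nM in a functional assay on HEK293 cells for agonist activity at G-protein coupled receptor 39 (Homo sapiens), read by scintillation proximity assay and inositol phosphate accumulation, with a stated time of 75 min, in the presence of a further agent that is not named here; on this read-out lower numbers stand for an effect already at smaller amounts and higher numbers for an effect only at larger amounts of compound. It stands level with compound 2 `Cc1nn(-c2ncnc3nc[nH]c23)c2c1C(OCc1ccccc1F)CC(=O)N2`, which gives 4 nM, and the two together hold the highest numbers of the three, while compound 1 `Cc1nn(-c2ncnc3nc[nH]c23)c2c1C(OC1CCCC1)CC(=O)N2`, with 2 nM, lies furthest away, though a 2.0-fold higher number from compound 1 to compound 3 (0.30 log units; within the scatter). Compound 4 `COc1ccc(CCOC2CC(=O)Nc3c2c(C)nn3-c2ncnc3nc[nH]c23)cc1` differs from compound 3 by 4-methoxybenzyl in place of 4-cyanophenyl on a saturated chain carbon bound to an oxygen on a saturated carbon. Among the measured compounds shown here, the steps that bear on this position are a 2.0-fold higher number from compound 1 to compound 2 (0.30 log units; within the scatter), a 2.0-fold higher number from compound 1 to compound 3 (0.30 log units; within the scatter) and no change at the digits printed from compound 2 to compound 3 (within the scatter), none of which leaves the scatter. Because no change at the digits printed from compound 2 to compound 3 (within the scatter), a further exchange at the same place is expected to give compound 4 no change at the digits printed from compound 3 to compound 4 (within the scatter), with no direction favoured. Compound 4 is therefore estimated at 4 nM, with a range from 1.5 nM to 12 nM.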

Compound 4, half-maximal effective concentration: 2 nM
The estimate for compound 4 lay 2.0-fold (0.30 log units) above the measured number, within the range that was stated.
By their numbers in this assay, from the lowest: compounds 1, 4, 2 and 3 (each within the scatter of the next).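

In this assay the place on the oxygen also accepts 2-(4-methoxyphenyl)ethyl, a longer group than either benzyl, since a 2.0-fold lower number from compound 3 to compound 4 (0.30 log units; within the scatter) and a 2.0-fold lower number from compound 2 to compound 4 (0.30 log units; within the scatter) and no change at the digits printed from compound 1 to compound 4 (within the scatter) all stay inside the scatter. All four groups shown at this place, cyclopentyl included, therefore cannot be told apart on this read-out. Nothing measured here accounts for this. The compounds shown leave open whether an amine or a carboxylic acid at the end of this chain, or a still longer chain, would stay equally close.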